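Phenyl for 2,3-dimethylphenyl on the piperazine nitrogen

This account rests on a few compounds, and the source may have more. Where it says the series, first, only, none or still open, it means among the compounds named here.

Compound 1 `Cc1nc(-c2ccccc2)c(C(=O)N2CCN(c3cccc(C)c3C)CC2)o1` carries the shared core with a 2,3-dimethylphenyl on the piperazine nitrogen. Within the data shown here, in a functional assay on HL-60 cells (Homo sapiens) for inhibition, read by MTT assay, with a stated time of 72 h (a higher number here means a weaker inhibitor, a lower number a stronger inhibitor), compound 1 gives 35 nM, the only single number so far. Compound 2 `CCc1nc(-c2ccc(OC)cc2)c(C(=O)N2CCN(c3cccc(Cl)c3)CC2)o1` is reported in this assay only as a limit of the assay, > 1000 nM, consistent with the limit of > 1000 nM in this assay, at which 1 of the 3 values shown sits. Compound 3 `CCc1nc(-c2ccc(OC)c(OC)c2)c(C(=O)N2CCN(c3cccc(Cl)c3)CC2)o1` is recorded in this assay as "not active" (no number reported), without a number. Among the measured compounds shown here, compounds 2 and 3 differ from compound 1 in several places at once, so they do not isolate any one change, and no step between measured compounds is available.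

Compound 4 `Cc1nc(-c2ccccc2)c(C(=O)N2CCN(c3ccccc3)CC2)o1` differs from compound 1 in one place: phenyl in place of 2,3-dimethylphenyl on an amine nitrogen in a ring. For the measured compounds named here, with no measured step to lean on, the expected step from compound 1 to compound 4 is a 3.1-fold higher number from compound 1 to compound 4 (0.50 log units; beyond the scatter), a modest loss in this assay, with the real possibility that it stays within the scatter. Compound 4 is therefore estimated at 110 nM in this assay, with a range from 25 nM to 600 nM.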

Compound 4, half-maximal inhibitory concentration: 39.1 nM
Compound 4: middle estimate off by 2.8-fold (0.45 log units), on the high side; the range from low to high includes it.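

In this assay, the series now has its first step that isolates one change: a 1.1-fold higher number from compound 1 to compound 4 (0.05 log units; within the scatter). At this place on the amine nitrogen in a ring, 2,3-dimethylphenyl and phenyl therefore cannot be told apart, and the two extra carbons of 2,3-dimethylphenyl are not required for a value of this size with the rest of compound 1 held fixed. Nothing available here gives a cause for this flat step.

From the compounds shown here alone, it remains open whether this tolerance extends to a different kind of group on that nitrogen, such as benzyl or acetyl, or to a carboxylic acid on the phenyl ring. Steps to compound 2 and compound 3 cannot be read, as each differs from compound 1 and compound 4 in several places at once.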